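A few compounds are considered here, and "the series" means these few. Any claim that something is new, unique, unknown or untested is made for them only; others in the source may bear on it.

Compounds in hand:

Compound 1, `COC(=O)CC/C=C\CC[C@H]1C(=O)C[C@@H](O)[C@@H]1/C=C/C[C@@](C)(O)C#CC1=CCCC1`. In a functional assay on the whole organism with Rattus norvegicus as the target (on this read-out lower numbers stand for an effect already at smaller amounts and higher numbers for an effect only at larger amounts of compound), compound 1 gives only a limit, > 3.16 mg/kg.
Compound 2, `CCCCC(C)(O)C/C=C/[C@H]1[C@H](O)CC(=O)[C@@H]1CC/C=C\CCC(=O)OC`. In this assay compound 2 gives 0.049 mg/kg.
Compound 3, `COC(=O)CC/C=C\CC[C@H]1C(=O)C[C@@H](O)[C@@H]1/C=C/C[C@@](C)(O)/C=C/C1CCCC1`. In this assay compound 3 gives 1.95 mg/kg.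

Compound 3 carries the highest of the two numbers, with compound 2 nearest: a 40-fold higher number from compound 2 to compound 3 (1.60 log units; beyond the scatter). Compound 4, `COC(=O)CC/C=C\CC[C@H]1C(=O)C[C@@H](O)[C@@H]1/C=C/C[C@@](C)(O)/C=C/C1CCC1`, differs from compound 3 by cyclobutyl in place of cyclopentyl on a double-bonded chain carbon bound to a double-bonded chain carbon, the same change read further out being 2-cyclopentylethenyl to 2-cyclobutylethenyl. Within the data shown here, no measured step swaps one ring for another; the nearest is an at least 1.6-fold lower number from compound 1 to compound 3 (0.20 log units; that floor lies within the scatter), which replaced the whole 2-(cyclopent-1-en-1-yl)ethynyl unit and stays within the scatter, while the large steps of an at least 64-fold lower number from compound 1 to compound 2 (1.80 log units; beyond the scatter) and a 40-fold higher number from compound 2 to compound 3 (1.60 log units; beyond the scatter) remove or add the ring altogether. A ring contraction alone is therefore expected to give no step beyond the scatter, a 1.0-fold higher number from compound 3 to compound 4 (0.01 log units; within the scatter). Compound 4 is estimated at 2 mg/kg, within 0.6 mg/kg to 6 mg/kg.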

Compound 4, dose for half-maximal effect: 0.53 mg/kg
Beside the measured number, compound 4's estimate is 3.8-fold (0.58 log units) above it; measured number outside the range, below it.
By their numbers in this assay, from the lowest: compound 2; then compound 4; then compound 3. At a limit, above all of these: compound 1.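

In this assay, among these compounds, ring size at this position matters on its own: cyclobutyl in place of cyclopentyl gives a 3.7-fold lower number from compound 3 to compound 4 (0.57 log units; beyond the scatter), a change that no earlier pair isolated. The ring contraction does not close the gap to the open chain, as 3-cyclobutyl-1-hydroxy-1-methylprop-2-en-1-yl in place of 1-hydroxy-1-methylpentyl gives an 11-fold higher number from compound 2 to compound 4 (1.03 log units; beyond the scatter). 2-Cyclobutylethenyl in place of 2-(cyclopent-1-en-1-yl)ethynyl gives an at least 5.9-fold lower number from compound 1 to compound 4 (0.77 log units; beyond the scatter), a floor whose starting value is a limit: the limit of > 3.16 mg/kg in this assay, at which 1 of the 4 values shown sits.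

From the compounds shown here alone, two ring sizes define no trend, so cyclopropyl and cyclohexyl remain open. Going by these compounds, how a phenyl or a longer chain would read on the same ethenyl also remains open.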